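A few compounds are considered here, and "the series" means these few. Any claim that something is new, unique, unknown or untested is made for them only; others in the source may bear on it.

Measured so far in a functional assay on NALM-6 cells (Homo sapiens) for inhibition, read by MTT assay, with a stated time of 48 h; a lower number here means a stronger inhibitor, a higher number a weaker inhibitor:
compound 1 `C=C1C(=O)N(c2ccccc2)N(c2ccccc2)C1c1ccccc1` gives 3820 nM;
compound 2 `C=C1C(=O)N(c2ccccc2)N(c2ccccc2)C1CC` gives 14900 nM;
compound 3 `C=C1C(=O)N(c2ccccc2)N(c2ccccc2)C1C` gives 6980 nM.

Among these three, compound 3 holds the second highest number in this assay. The gap to its nearest neighbour, a 1.8-fold higher number from compound 1 to compound 3 (0.26 log units; within the scatter), lies within the scatter; the gap to its furthest, a 2.1-fold lower number from compound 2 to compound 3 (0.33 log units; beyond the scatter), lies beyond it. Compound 4 `C=CCC1C(=C)C(=O)N(c2ccccc2)N1c1ccccc1` has not yet been measured. It differs from compound 3 by vinyl in place of hydrogen on a saturated chain carbon bound to a saturated ring carbon; cut one bond further out, the same difference reads methyl to allyl. The step that bears most directly on it is a 2.1-fold lower number from compound 2 to compound 3 (0.33 log units; beyond the scatter), where the shorter chain on that carbon came with the lower number. The two replacements of phenyl, a 3.9-fold higher number from compound 1 to compound 2 (0.59 log units; beyond the scatter) and a 1.8-fold higher number from compound 1 to compound 3 (0.26 log units; within the scatter), point the same way, the longer chain carrying the higher number. Lengthening the chain further is therefore expected to raise the number in this assay by a modest step, about a 1.7-fold higher number from compound 3 to compound 4 (0.24 log units; within the scatter). Compound 4 is estimated at 12000 nM, with a range from 5000 nM to 30000 nM.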

Compound 4, half-maximal inhibitory concentration: 740 nM
Beside the measured number, compound 4's estimate is 16-fold (1.21 log units) above it; measured number below the stated range.
By their numbers in this assay, from the lowest: compound 4; then compounds 1 and 3 (each within the scatter of the next); then compound 2.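

In this assay, a longer group on a saturated chain carbon bound to a saturated ring carbon no longer tracks with a higher number: vinyl in place of hydrogen gives (a 9.4-fold lower number from compound 3 to compound 4 (0.97 log units; beyond the scatter)) and vinyl in place of methyl gives (a 20-fold lower number from compound 2 to compound 4 (1.30 log units; beyond the scatter)), whereas the earlier ethyl and methyl compounds ran the other way. Allyl also surpasses phenyl on the saturated ring carbon (a 5.2-fold lower number from compound 1 to compound 4 (0.71 log units; beyond the scatter)), leaving compound 4 with the lowest number of the four, so compound 2 and compound 4 together rule out any simple order by chain length among these compounds. Nothing shown gives a reason for this reversal.

Going by these compounds, it remains open whether the double bond or the added chain length carries the drop, which a propyl group in the same place would separate. On these data alone, whether a longer alkenyl chain or a benzyl group would go further also remains open.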